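The compounds below may be only part of what the source reports. "The series", "measured", "known", "first", "only" and "open" are said of these compounds alone.

Compound 1 `CCNC(=S)N/N=C/c1cccc2ccccc12` is a thiosemicarbazone built on a naphthalene-derived core, and in a functional assay on B16 cells (Mus musculus), read by spectrophotometry, with a stated time of 3 days (a lower number here means a stronger inhibitor, a higher number a weaker inhibitor), compound 1 gives 1100 nM. Only one companion has been measured so far: compound 2 `COc1ccccc1NC(=S)N/N=C/c1cccc2ccccc12`, which in this assay gives 920 nM. On these two numbers compound 1 stands highest, but the step of a 1.2-fold lower number from compound 1 to compound 2 (0.08 log units; within the scatter) is within the scatter, so the two values cannot be told apart.

Compound 3 `CN(/N=C/c1cccc2ccccc12)C(N)=S` has not yet been measured. It differs from compound 1 in the thiosemicarbazide portion: a group of 5 heavy atoms (2 carbon, 2 nitrogen, 1 sulfur; no ring) in place of a group of 6 heavy atoms (3 carbon, 2 nitrogen, 1 sulfur; no ring), on a double-bonded nitrogen. Among the measured compounds shown here, the only measured step, from compound 1 to compound 2, swaps the ethyl for 2-methoxyphenyl on an amide-type nitrogen, a different place from the double-bonded nitrogen changed here, and it was within the scatter. For the measured compounds named here, no measured step therefore speaks directly to this change, and the direction in this assay cannot be read from the data. The estimated step of a 1.4-fold higher number from compound 1 to compound 3 (0.13 log units; within the scatter) is expected to be small, with a wide range in either direction. Compound 3 is estimated at 1500 nM, between 400 nM and 6000 nM.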

Compound 3, half-maximal inhibitory concentration: 1600 nM
Beside the measured number, compound 3's estimate is 1.1-fold (0.03 log units) below it; measured number inside the range.
By their numbers in this assay, from the lowest: compounds 2, 1 and 3 (each within the scatter of the next).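

In this assay, the change from a group of 6 heavy atoms with 2 hydrogen-bond donors to a group of 5 heavy atoms with 1 hydrogen-bond donor, on a double-bonded nitrogen, gives a 1.5-fold higher number from compound 1 to compound 3 (0.16 log units; within the scatter) and so leaves compound 1 and compound 3 indistinguishable. Among the compounds shown here, this is the first measured look at this place, as the earlier step concerned an amide-type nitrogen, and it shows that this small change to the thiosemicarbazide portion can be made without a difference that this assay can resolve. No supporting measurement is available to explain this result.

The compounds shown leave open whether a bigger change at this place, such as a longer chain, an amine or a carboxylic acid on the double-bonded nitrogen, would move the number beyond the scatter. They also leave open how the change in compound 3 would behave with the 2-methoxyphenyl group of compound 2 in the same molecule, since each change is seen here only on its own.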